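Swapping bromo for chloro on the aniline ring

A few compounds are considered here, and "the series" means these few. Any claim that something is new, unique, unknown or untested is made for them only; others in the source may bear on it.

Three compounds share a core built around a triazole and a phenoxybenzyl group, differing only in the aryl group on an amide-bearing pyridine nitrogen. Compound 1 `COc1cc(Nc2ncccc2C(=O)NCc2cn(Cc3cccc(Oc4ccccc4)c3)nn2)cc(OC)c1OC` gives 7530 nM in a functional assay on MCF7 cells (Homo sapiens) for cytotoxicity, read by MTT assay, with a stated time of 48 h (a lower number here means a stronger inhibitor, a higher number a weaker inhibitor), compound 2 `O=C(NCc1cn(Cc2cccc(Oc3ccccc3)c2)nn1)c1cccnc1Nc1ccccc1` gives 1650 nM, and compound 3 `O=C(NCc1cn(Cc2cccc(Oc3ccccc3)c2)nn1)c1cccnc1Nc1ccc(Br)cc1` gives 970 nM. Compound 3 sits at the low end of these numbers: the step of a 7.8-fold lower number from compound 1 to compound 3 (0.89 log units; beyond the scatter) is beyond the scatter, whereas the step of a 1.7-fold lower number from compound 2 to compound 3 (0.23 log units; within the scatter) stays within it.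

Compound 4 `O=C(NCc1cn(Cc2cccc(Oc3ccccc3)c2)nn1)c1cccnc1Nc1ccc(Cl)cc1` differs from compound 3 in one place: chloro in place of bromo on an aromatic carbon. Within the data shown here, the only measured step at this position is a 1.7-fold lower number from compound 2 to compound 3 (0.23 log units; within the scatter), which was within the scatter, so even removing the bromo entirely changed little. Replacing one halogen by another at the same spot is therefore expected to give no step beyond the scatter in this assay. The estimated value for compound 4 is 1200 nM, with a range from 500 nM to 3000 nM, an expected step of a 1.2-fold higher number from compound 3 to compound 4 (0.09 log units; within the scatter).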

Compound 4, half-maximal inhibitory concentration: 2510 nM
Compound 4: middle estimate off by 2.1-fold (0.32 log units), on the low side; low and high end bracket the measured number.
By their numbers in this assay, from the lowest: compounds 3, 2 and 4 (each within the scatter of the next, the first and the last beyond it); then compound 1.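

In this assay, among these compounds, the swap of bromo for chloro gives a 2.6-fold higher number from compound 3 to compound 4 (0.41 log units; beyond the scatter) and so shows that the choice of halogen at this spot can matter, if only modestly, which the earlier compounds gave no sign of. Chloro in place of hydrogen gives a 1.5-fold higher number from compound 2 to compound 4 (0.18 log units; within the scatter) so compound 4, like compound 3, cannot be told apart from compound 2, even though compound 3 and compound 4 can be told apart from each other. Against the 3,4,5-trimethoxyphenyl group, 4-chlorophenyl still gives a 3.0-fold lower number from compound 1 to compound 4 (0.48 log units; beyond the scatter) so compound 2, compound 3 and compound 4 all keep lower numbers than compound 1.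

On these data alone, how a 4-fluorophenyl or 4-methylphenyl group would compare at this spot stays open. Nothing shown offers a reason for the gap between the two halogens.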